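The source may hold more compounds than are shown below. What is called first, only, known or untested is meant among the compounds shown, and "the series" means these compounds.

Measured so far:
compound 1 `COc1ccc(/C=C2\CN(C(=S)SCc3cn(Cc4ccccc4F)nn3)C/C(=C\c3ccc(OC)cc3)C2=O)cc1`: 31500 nM
compound 2 `COc1ccc(/C=C2\CN(Cc3cn(Cc4cccc(Cl)c4)nn3)C/C(=C\c3ccc(OC)cc3)C2=O)cc1`: 32500 nM

Both numbers come from a functional assay on PC-3 cells (Homo sapiens) for cytotoxicity, read by MTT assay, with a stated time of 24 h (on this read-out higher numbers stand for weaker inhibition and lower numbers for stronger inhibition), and lie within the scatter of each other, so compound 2 stands level with compound 1 on the numbers available. Going by the values given here, no step between measured compounds is available to guide the next reading.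

Compound 3 `COc1ccc(/C=C2\CN(Cc3cn(Cc4ccccc4F)nn3)C/C(=C\c3ccc(OC)cc3)C2=O)cc1` differs from compound 2 by 2-fluorophenyl in place of 3-chlorophenyl on a saturated chain carbon bound to an aromatic nitrogen and the same change, cut one bond further out, reads 3-chlorobenzyl to 2-fluorobenzyl. In this assay no step beyond the scatter is expected, in either direction. The expectation therefore stays close to compound 2 at 32500 nM and rests on little else. The estimated change is a 1.1-fold lower number from compound 2 to compound 3 (0.03 log units; within the scatter) and it is expected to stay within the scatter. Compound 3 is expected at 30000 nM with 13000 nM and 65000 nM as the estimated lower and upper ends.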

Compound 3, half-maximal inhibitory concentration: 39900 nM
For compound 3 the middle estimate is 1.3-fold (0.12 log units) below the measured one, within the range that was stated.
By their numbers in this assay, from the lowest: compounds 1, 2 and 3 (each within the scatter of the next).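

In this assay, going by these compounds alone, the swap of 3-chlorobenzyl for 2-fluorobenzyl gives the first readable step at this position, on a saturated chain carbon bound to an aromatic nitrogen: a 1.2-fold higher number from compound 2 to compound 3 (0.09 log units; within the scatter). Between compound 2 and compound 3, therefore, replacing 3-chlorophenyl with 2-fluorophenyl does not move the read-out beyond the scatter, and this pair gives no sign that the position responds to this change. No measurement available here bears on why the two compounds read alike.

The step changes the halogen and its place on the ring at once, so the two changes cannot be separated. From the compounds shown here alone, whether an unsubstituted benzyl, a benzyl carrying a carboxylic acid or an amine, or a longer chain such as phenethyl would read differently remains open.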